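A Trifluorophenyl Group in Place of a Dimethoxyphenyl Group

A few compounds are considered here, and "the series" means these few. Any claim that something is new, unique, unknown or untested is made for them only; others in the source may bear on it.

Three compounds have been measured in a functional assay on PC-3 cells (Homo sapiens) for cytotoxicity, read by MTT assay, with a stated time of 72 h; a higher number here means a weaker inhibitor, a lower number a stronger inhibitor:

Compound 1 `COc1ccc(C(=O)c2cc(OC)c(OC)c(OC)c2)cc1NC(=O)/C=C/c1ccc(OC)c(OC)c1`: 7500 nM
Compound 2 `C#CCOc1cccc(/C=C/C(=O)Nc2cc(C(=O)c3cc(OC)c(OC)c(OC)c3)ccc2OC)c1`: 13100 nM
Compound 3 `COc1ccc(/C=C/C(=O)Nc2cc(C(=O)c3cc(OC)c(OC)c(OC)c3)cc(OC)c2OC)cc1OC`: 5400 nM

Compound 3 gives the lowest number of the three. Its closest neighbour is compound 1, with a step of a 1.4-fold lower number from compound 1 to compound 3 (0.14 log units; within the scatter) that adds a methoxy on an aromatic carbon. Compound 2 sits furthest from it: compound 2 gives 13100 nM against the value of compound 3, a gap that goes beyond the scatter.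

Compound 4 `COc1cc(C(=O)c2cc(OC)c(OC)c(OC)c2)cc(NC(=O)/C=C/c2cc(F)c(F)c(F)c2)c1OC` differs from compound 3 in one place: 3,4,5-trifluorophenyl in place of 3,4-dimethoxyphenyl on a double-bonded chain carbon bound to a double-bonded chain carbon. Going by the values given here, the only measured step that touches the same place is the one from compound 1 to compound 2, where another group replaced the 3,4-dimethoxyphenyl and gave a 1.7-fold higher number from compound 1 to compound 2 (0.24 log units; within the scatter). That change barely moved the number, so a modest shift is the most that this one precedent supports. The expected step is a 1.3-fold higher number from compound 3 to compound 4 (0.11 log units; within the scatter), which would again stay within the scatter. Compound 4 is therefore estimated at 7000 nM, with a range from 2500 nM to 20000 nM.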

Compound 4, half-maximal inhibitory concentration: 7400 nM
Compound 4: the middle estimate sits 1.1-fold (0.02 log units) below what was measured; measured number inside the range.
By their numbers in this assay, from the lowest: compounds 3, 4, 1 and 2 (each within the scatter of the next, the first and the last beyond it).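

In this assay, the change at this place gives a 1.4-fold higher number from compound 3 to compound 4 (0.14 log units; within the scatter), so the number holds within the scatter even though the entering 3,4,5-trifluorophenyl has 0 hydrogen-bond acceptors where the leaving 3,4-dimethoxyphenyl has 2. The only earlier replacement here, on the core of compound 1, gave a 1.7-fold higher number from compound 1 to compound 2 (0.24 log units; within the scatter), so this is a second, quite different ring at the same place on a second core, and again the step stays within the scatter; on these two steps, this place tolerates both swaps in this cell assay, though two steps are too few to make that a general rule. No supporting measurement is available to explain why the number holds.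

On these data alone, both replacements keep an aromatic ring of carbon on the chain, so it remains open whether a group with no such ring, such as a plain methyl, would move the number beyond the scatter. As far as these compounds go, it is equally open whether a ring carrying an amine or a carboxylic acid at this place would do so.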